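Swapping the benzylsulfanyl halogen in a bromophenyl amide series

The source may hold more compounds than are shown below. What is called first, only, known or untested is meant among the compounds shown, and "the series" means these compounds.

Of the compounds shown here, three have been measured in a functional assay on the whole organism (artery, strain albino) with Rattus norvegicus as the target, with a stated time of 600 min, at a dose of 10 mg/kg by the oral route; on this read-out lower numbers stand for less inhibition and higher numbers for more inhibition at the one dose given (going by the name of the read-out). Compound 1 `CC1=C(C(=O)Nc2ccc(Br)cc2)C(c2ccc(Cl)cc2Cl)N=C(SCc2ccc(F)cc2)N1` gives 33.3%, compound 2 `COc1ccc(C2N=C(SCc3ccccc3)NC(C)=C2C(=O)Nc2ccc(Br)cc2)cc1` gives 11.3%, and compound 3 `COc1ccc(C2N=C(SCc3cccc(Cl)c3)NC(C)=C2C(=O)Nc2ccc(Br)cc2)cc1` gives 32.8%, which stands second highest of the three, within the scatter of compound 1 and beyond the scatter above compound 2. Among the compounds with values here, the one single-point step is a number 21.5 percentage points higher from compound 2 to compound 3 (beyond the scatter). Compound 4 `COc1ccc(C2N=C(SCc3ccc(F)cc3)NC(C)=C2C(=O)Nc2ccc(Br)cc2)cc1` differs from compound 3 by 4-fluorophenyl in place of 3-chlorophenyl on a saturated chain carbon bound to a sulfur. Within the data shown here, no measured step covers this exchange directly; compound 1, which carries the 4-fluorobenzyl group on another core, and compound 3 show values within the scatter of each other. Compound 4 is therefore expected to stay close to compound 3, with a step of a number 4.8 percentage points lower from compound 3 to compound 4 (within the scatter), at an estimated 28% ranging from 12% to 45%.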

Compound 4, a percentage reported as inhibition, in the whole organism at one dose (the size of the read-out at that dose, not a potency): 24.1%
Beside the measured number, compound 4's estimate is 3.9 percentage points above it; the measured number falls inside the stated range.
By their numbers in this assay, from the lowest: compound 2; then compounds 4, 3 and 1 (each within the scatter of the next).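

The 4-fluorobenzyl group on sulfur also stands clear of the unsubstituted benzyl group (a number 12.8 percentage points higher from compound 2 to compound 4 (beyond the scatter)), so the earlier chloro step is no longer the only halogen result at this position. Exchanging 3-chlorobenzyl for 4-fluorobenzyl does not separate the two halogenated groups (a number 8.7 percentage points lower from compound 3 to compound 4 (within the scatter)), and neither does the 4-methoxyphenyl for 2,4-dichlorophenyl exchange on the saturated ring carbon (a number 9.2 percentage points lower from compound 1 to compound 4 (within the scatter)). Nothing available explains these numbers. From the compounds shown here alone, whether a methoxy group or an amine on the benzyl ring, or a longer chain in place of benzyl, would hold the level above compound 2 remains open.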